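The source may report more compounds than this note shows. Statements on the series, on what has been measured and on what is new or still open speak of the compounds shown alone.

The compounds share the core shown in compound 1 `O=C(CCl)Nc1ccc(-c2nc3cc(C(F)(F)F)ccc3[nH]2)cc1`, a benzimidazole-type scaffold that the data leave unnamed; they differ only in the group carried on the outer aromatic ring. In an ADME assay on MDBK cells (Bos taurus) for cytotoxicity, read by MTT assay, with a stated time of 96 h (a higher number here means that more compound is tolerated, a lower number that less compound is tolerated), compound 1 gives 17000 nM. Compound 2 `Oc1ccc(-c2nc3cc(C(F)(F)F)ccc3[nH]2)cc1` gives 51000 nM in this assay. Compound 3 `CCC(=O)Nc1ccc(-c2nc3cc(C(F)(F)F)ccc3[nH]2)cc1` reaches only a limit of the assay, > 100000 nM, so its exact number is not known (the limit of > 100000 nM in this assay, at which 1 of the 3 values shown sits). Compound 3 therefore stands at the most tolerated end of the three, with the sequence a 3.0-fold higher number from compound 1 to compound 2 (0.48 log units; beyond the scatter), an at least 5.8-fold higher number from compound 1 to compound 3 (0.76 log units; beyond the scatter) and an at least 1.9-fold higher number from compound 2 to compound 3 (0.29 log units; that floor lies within the scatter) describing the measured swaps at that aromatic carbon. Compound 4 `O=[N+]([O-])c1ccc(-c2nc3cc(C(F)(F)F)ccc3[nH]2)cc1` carries the change (nitro in place of propanoylamino on an aromatic carbon). Within the data shown here, no measured step involves a nitro group, so the nearest guides are the swaps of one aromatic substituent for another, which were modest in size and all moved toward greater tolerance; a nitro group lacks the hydrogen-bond donor of the propanoylamino group. A modest step is therefore expected in this assay, most likely downward from the limit, an at least 1.4-fold lower number from compound 3 to compound 4 (0.15 log units; that floor lies within the scatter). Compound 4 is estimated at 70000 nM in this assay, within a range from 20000 nM to 200000 nM.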

Compound 4, half-maximal cytotoxic concentration: 6000 nM
The estimate for compound 4 lay 12-fold (1.07 log units) above the measured number, outside the stated range (below it).
By their numbers in this assay, from the lowest: compound 4; then compound 1; then compound 2. At a limit, above all of these: compound 3.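

Compound 4 has the lowest number of the four in this assay, and the position now shows a clear move toward less tolerance, seen in an at least 16-fold lower number from compound 3 to compound 4 (1.22 log units; beyond the scatter), an 8.5-fold lower number from compound 2 to compound 4 (0.93 log units; beyond the scatter) and a 2.8-fold lower number from compound 1 to compound 4 (0.45 log units; beyond the scatter). The earlier compounds shown here showed only that ((chloromethyl)carbonyl)amino was the least tolerated group at this aromatic carbon, whereas nitro now falls beyond it, so the reactive-looking chain of compound 1 does not mark the bottom of the series. The first of these steps is only a floor, as compound 3 stands at a limit: the limit of > 100000 nM in this assay, at which 1 of the 4 values shown sits.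

The compounds shown leave open where an amine, a nitrile or a carboxylic acid on this aromatic carbon would fall relative to nitro and hydroxy. They also leave open whether this order holds when trifluoromethyl on the shared core gives way to another group.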